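One Methyl Removed from Two Cores in Cytotoxicity Testing

The source may report more compounds than this note shows. Statements on the series, on what has been measured and on what is new or still open speak of the compounds shown alone.

Measured in a functional assay on WRL68 cells (Homo sapiens) for cytotoxicity, read by MTT assay, with stated times of 6 h and 48 h; on this read-out higher numbers stand for weaker inhibition and lower numbers for stronger inhibition:
- compound 1 `Cn1c(/C=C/C(=O)c2ccccc2O)cc(Br)c1Br` gives 330 nM
- compound 2 `O=C(/C=C/c1cc(Br)c(Br)[nH]1)c1ccccc1O` gives 1420 nM
- compound 3 `Cn1c(-c2cc(-c3ccc[nH]3)no2)cc(Br)c1Br` gives >= 100000 nM, which is a limit of the assay and not a number

Compound 2 differs from compound 1 by hydrogen in place of methyl on an aromatic nitrogen, and a 4.3-fold higher number from compound 1 to compound 2 (0.63 log units; beyond the scatter). Compound 3 sits at the limit of >= 100000 nM in this assay, at which 1 of the 3 values shown sits. How the core of compound 3 differs from the core of compound 1 is not broken down here. Compound 4 `Brc1cc(-c2cc(-c3ccc[nH]3)no2)[nH]c1Br` has not been measured; it differs from compound 3 by hydrogen in place of methyl on an aromatic nitrogen, the same change as between compound 1 and compound 2, with the surroundings described in identical words. Beside that earlier step, the step of a number no higher from compound 3 to compound 4 (the limit leaves the size open) is expected to be small, because compound 3 already stands at the limit of >= 100000 nM in this assay, at which 1 of the 3 values shown sits. Compound 4 is therefore estimated at about 100000 nM in this assay, most likely again reported only as a limit.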

Compound 4, half-maximal inhibitory concentration: >= 100000 nM
Compound 4 gave a limit, no number; the forecaster's own chance of this, stated with the estimate: 80%; the middle value lies on the limit itself.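

No step from compound 3 to compound 4 can be read, since both are reported only as a limit: the limit of >= 100000 nM in this assay, at which 2 of the 4 values shown sit.

On these data alone, whether hydrogen in place of methyl on an aromatic nitrogen changes anything on this core stays open.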